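A few compounds are considered here, and "the series" means these few. Any claim that something is new, unique, unknown or untested is made for them only; others in the source may bear on it.

The set brings together three measured compounds and one that awaits measurement in a toxicity assay on the whole organism (strain Icem-CET (SPF Caw)) for cytotoxicity, with Mus musculus as the target; a higher number here means that more compound is needed for the effect, a lower number that less compound is needed. Compound 1, `C=CCNC(=O)/C(C)=C(/C)c1ccc(Br)cc1`, gives 400 mg/kg in this assay. Compound 2, `C/C(C(=O)NC1CC1)=C(\C)c1ccc(C)cc1`, gives 280 mg/kg. Compound 3, `C=CCNC(=O)/C(C)=C(\C)c1cc(OC)c(OC)c(OC)c1`, gives 110 mg/kg, the lowest of the three numbers; its nearest neighbour is compound 2, whose number is higher by a gap beyond the usual scatter, and compound 1 stands further away still, also beyond the scatter.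

Compound 4, `C#CCNC(=O)/C(C)=C(\C)c1cc(OC)c(OC)c(OC)c1`, is the compound not yet measured. It differs from compound 3 in one place: ethynyl in place of vinyl on a saturated chain carbon bound to an amide-type nitrogen. Going by the values given here, no pair of measured compounds in this set differs by this change alone, so there is no measured step to lean on, and the shared core is left untouched by the change. With nothing in the measured compounds pointing one way or the other, compound 4 is expected to sit close to compound 3 in this assay. The expected step is a 1.1-fold lower number from compound 3 to compound 4 (0.04 log units; within the scatter), which amounts to none beyond the scatter, with at most a slight lean toward a lower number. Compound 4 is therefore estimated at 100 mg/kg in this assay, with a range from 50 mg/kg to 250 mg/kg.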

Compound 4, dose for half-maximal effect: 160 mg/kg
Compound 4: middle estimate off by 1.6-fold (0.20 log units), on the low side, within the range that was stated.
By their numbers in this assay, from the lowest: compounds 3, 4, 2 and 1 (each within the scatter of the next, the first and the last beyond it).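

In this assay, going by these compounds alone, ethynyl in place of vinyl on a saturated chain carbon bound to an amide-type nitrogen is the first change in this set that can be read on its own, and it gives a 1.5-fold higher number from compound 3 to compound 4 (0.16 log units; within the scatter) with the rest of the structure held fixed. The earlier compounds shown here differ from one another in more than one place, so they could not say what this position tolerates; this pair shows that, on the shared core of compound 3, a triple bond can stand in place of a double bond, with the same two carbon atoms, without a difference that rises above the scatter. No measurement shown here offers a reason for this outcome, or for the small gap between the two numbers.

From the compounds shown here alone, what remains open is whether the same change reads alike on the cores of compound 1 and compound 2, since this single pair cannot show it. Also open, going by these compounds, is how this position responds to a group of another kind in place of vinyl on that chain carbon, such as an ethyl group, a longer chain, an amine or a carboxylic acid.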